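Sulfonylacetic acid series: aryl-ring swap at the benzyl ether

A few compounds are considered here, and "the series" means these few. Any claim that something is new, unique, unknown or untested is made for them only; others in the source may bear on it.

Measured compounds:
compound 1 `Cc1ccccc1-c1cccc(COc2ccc(S(=O)(=O)CC(=O)O)cc2)c1`, 46.8 nM
compound 2 `O=C(O)CS(=O)(=O)c1ccc(OCc2cccc(-c3ccccc3)c2)cc1`, 288 nM
compound 3 `O=C(O)CS(=O)(=O)c1ccc(OCc2cccc(Oc3ccccc3)c2)cc1`, 97.7 nM

In a functional assay on CHO cells for agonist activity at Free fatty acid receptor 1 (Homo sapiens), read by FLIPR and calcium flux (a higher number here means that more compound is needed for the effect, a lower number that less compound is needed), compound 3 gives 97.7 nM, the second highest of the three numbers; compound 1 sits a 2.1-fold higher number from compound 1 to compound 3 (0.32 log units; beyond the scatter) away, compound 2 at a 2.9-fold lower number from compound 2 to compound 3 (0.47 log units; beyond the scatter).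

Compound 4 `Cc1ccc(C)n1-c1cccc(COc2ccc(S(=O)(=O)CC(=O)O)cc2)c1` differs from compound 3 by 2,5-dimethyl-1H-pyrrol-1-yl in place of phenoxy on an aromatic carbon. Among the measured compounds shown here, no measured step exchanges a six-membered ring for a five-membered one, so the bearing steps are indirect. The shift a 2.9-fold lower number from compound 2 to compound 3 (0.47 log units; beyond the scatter) and the shift a 6.2-fold higher number from compound 1 to compound 2 (0.79 log units; beyond the scatter) show that what hangs at this carbon moves this assay by modest amounts in either direction, and the 2-methylphenyl of compound 1 gave the lowest number of the three. The 2,5-dimethyl-1H-pyrrol-1-yl group also carries two methyls on its ring, so the outcome is expected to lie between the numbers of compound 3 and compound 1, the step of a 1.6-fold lower number from compound 3 to compound 4 (0.21 log units; within the scatter) expected to be modest and toward a lower number. For compound 4 the estimate is 60 nM with a range of 20 nM to 200 nM.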

Compound 4, half-maximal effective concentration: 129 nM
Beside the measured number, compound 4's estimate is 2.2-fold (0.33 log units) below it; the measured number falls inside the stated range.
By their numbers in this assay, from the lowest: compound 1; then compounds 3 and 4 (each within the scatter of the next); then compound 2.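

In this assay, a five-membered aromatic ring with one nitrogen stands on this aromatic carbon in place of phenoxy without a readable shift (a 1.3-fold higher number from compound 3 to compound 4 (0.12 log units; within the scatter)), so among these compounds a six-membered ring of carbon only is not needed to hold that level. Against the other two aryl groups the readings are a 2.2-fold lower number from compound 2 to compound 4 (0.35 log units; beyond the scatter) and a 2.8-fold higher number from compound 1 to compound 4 (0.44 log units; beyond the scatter), so the two methyls of the 2,5-dimethyl-1H-pyrrol-1-yl group do not match the number given by the 2-methylphenyl group. No measurement here bears on why these groups differ.

As far as these compounds go, how a 2-methylphenoxy group would read remains open, and with it whether the gain tied to the methyl carries over to the oxygen-linked ring. An unsubstituted pyrrol-1-yl group or a pyridyl ring at this carbon would separate the weight of the two methyls from that of the ring nitrogen.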